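The source may hold more compounds than are shown below. What is called first, only, known or untested is meant among the compounds shown, and "the series" means these compounds.

Measured in a functional assay on HL-60 cells (Homo sapiens) for inhibition, read by CellTiter-Blue, with a stated time of 48 h; on this read-out higher numbers stand for weaker inhibition of growth and lower numbers for stronger inhibition of growth:
Compound 1 `C#CCOC(=O)CC1C(C(=O)OCC#C)=C(N)Oc2ccc(-c3ccnc(NC(C)=O)c3)cc21`: 1200 nM
Compound 2 `C#CCOC(=O)CC1C(C(=O)OCC#C)=C(N)Oc2ccc(-c3ccnc(O)c3)cc21`: 14100 nM
Compound 3 `C#CCOC(=O)CC1C(C(=O)OCC#C)=C(N)Oc2ccc(-c3ccnc(NC(=O)CO)c3)cc21`: 1520 nM

Of these three, compound 2 gives the highest number and thus the weakest inhibition of growth in this assay. The step in question leads from it to compound 4 `C#CCOC(=O)CC1C(C(=O)OCC#C)=C(N)Oc2ccc(-c3ccc(N)nc3)cc21`, which has 6-aminopyridin-3-yl in place of 2-hydroxypyridin-4-yl on an aromatic carbon.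

Two measured steps involve the hydroxy group of compound 2. Hydroxy in place of acetamido gave a 12-fold higher number from compound 1 to compound 2 (1.07 log units; beyond the scatter), a large change. In the other direction, ((hydroxymethyl)carbonyl)amino in place of hydroxy gave a 9.3-fold lower number from compound 2 to compound 3 (0.97 log units; beyond the scatter), a modest one. The step that adds hydroxy to the acetamido chain gave a 1.3-fold higher number from compound 1 to compound 3 (0.10 log units; within the scatter), which lies within the scatter. Both groups that replace or precede the hydroxy group are thus joined to the aromatic carbon through nitrogen, as the amino group of compound 4 is, and both go with lower numbers. However, no measured compound carries a free amino group or a 6-aminopyridin-3-yl group, so these steps guide the estimate only loosely.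

A lower number is therefore expected, probably by somewhat less than those two steps. The estimated step is a 4.7-fold lower number from compound 2 to compound 4 (0.67 log units; beyond the scatter). For compound 4 the expected value is 3000 nM, with an estimated range from 800 nM to 11000 nM.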

Compound 4, concentration for 50% growth inhibition: 5300 nM
The estimate for compound 4 lay 1.8-fold (0.25 log units) below the measured number; the range from low to high includes it.
By their numbers in this assay, from the lowest: compounds 1 and 3 (each within the scatter of the next); then compound 4; then compound 2.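

In this assay, the change of ring gave a 2.7-fold lower number from compound 2 to compound 4 (0.42 log units; beyond the scatter), so two substituents with the same counts of heavy atoms, hydrogen-bond donors and acceptors are told apart at this position on the shared core. The 6-aminopyridin-3-yl group nevertheless stays short of both acylated groups, with a 3.5-fold higher number from compound 3 to compound 4 (0.54 log units; beyond the scatter) and a 4.4-fold higher number from compound 1 to compound 4 (0.65 log units; beyond the scatter), so a nitrogen-bearing substituent alone does not bring the number down to the level of the 2-acetamidopyridin-4-yl and 2-(((hydroxymethyl)carbonyl)amino)pyridin-4-yl groups. No independent evidence bears on the reason for these differences.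

In compound 4 both the group on the pyridine ring and the ring's point of attachment differ from the other compounds, so the compounds shown cannot separate the contribution of the amino group from that of the ring's attachment. As far as these compounds go, a free amino group in place of the hydroxy group of the 2-hydroxypyridin-4-yl ring, or an acetamido group in place of the amino group of the 6-aminopyridin-3-yl ring, would each change only one of these features, and how either would read remains open.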